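Swapping the Bromophenyl Tail for a Fluorophenyl One

This account rests on a few compounds, and the source may have more. Where it says the series, first, only, none or still open, it means among the compounds named here.

Compound 1, `O=C(COc1ccc(C(=O)/C=C/c2ccccc2Br)cc1)N[C@H]1CCOC1=O`, was tested in a functional assay on DU-145 cells (Homo sapiens) for antiproliferative activity, read by MTT assay, with a stated time of 72 h; on this read-out lower numbers stand for stronger inhibition and higher numbers for weaker inhibition. In this assay compound 1 gives 3540 nM. Among the measured compounds shown here, this is the only full number obtained so far; the one other result is a limit rather than a number (the limit of > 64000 nM in this assay, at which 1 of the 2 values shown sits). Compound 2, `O=C(CNc1ccccc1)N[C@H]1CCOC1=O`, is that other entry. In this assay compound 2 reaches only the limit > 64000 nM, so no number is known for it.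

Compound 3, `O=C(COc1ccc(C(=O)/C=C/c2cccc(F)c2)cc1)N[C@H]1CCOC1=O`, has not yet been measured. It differs from compound 1 in a single place: 3-fluorophenyl in place of 2-bromophenyl on a double-bonded chain carbon bound to a double-bonded chain carbon. The rest of the shared core stays the same. For the measured compounds named here, no two measured compounds differ in just one place, so there is no measured step to lean on. The change swaps one substituted phenyl ring for another at the end of the double-bonded chain, and a small shift toward weaker inhibition, at most near the edge of the usual scatter, is expected a 1.3-fold higher number from compound 1 to compound 3 (0.10 log units; within the scatter). For compound 3 the expected value in this assay is estimated at 4500 nM, with a likely range from 1800 nM to 11000 nM.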

Compound 3, half-maximal inhibitory concentration: 17200 nM
Compound 3: the middle estimate sits 3.8-fold (0.58 log units) below what was measured; the whole stated range lies below it.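

Among the compounds shown here, this is the first step that can be read, and it shows that the tail at the end of the double-bonded chain matters in this assay: putting 3-fluorophenyl in place of 2-bromophenyl gives a 4.9-fold higher number from compound 1 to compound 3 (0.69 log units; beyond the scatter). The two groups match in the counts computed for them, with the same number of heavy atoms, one carbon-only aromatic ring and no hydrogen-bond donors or acceptors, so those counts do not predict this loss of inhibition, even though the rest of the shared core stays the same. Nothing measured here gives a reason for the step.

The swap changes both the halogen and its place on the ring, so the compounds shown leave open which of the two accounts for the weaker inhibition of compound 3. Also open, as far as these compounds go, is how this tail would behave with no halogen at all, as a plain phenyl ring, or with a different group on the ring, such as a methoxy group, an amine or a carboxylic acid.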